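Moving the Chlorine Around the Aryl Ring

The source may report more compounds than this note shows. Statements on the series, on what has been measured and on what is new or still open speak of the compounds shown alone.

Compound 1 `CCC(C(=O)N1CCN(c2ccccc2Cl)CC1)N1C(=O)CCC1=O` stands highest of three compounds examined in a functional assay on the whole organism (strain Swiss) with Mus musculus as the target, in the maximal electroshock model, with a stated time of 1 h, at a dose of 300 mg/kg by the intraperitoneal route (on this read-out higher numbers stand for a stronger effect at the one dose given and lower numbers for a weaker effect), where compound 1 gives 50%. Its nearest neighbour, compound 3 `CC(C(=O)N1CCN(c2ccccc2Cl)CC1)N1C(=O)CCC1=O`, gives 25%, while the most distant, compound 2 `CCC(C(=O)N1CCN(c2ccccc2C(F)(F)F)CC1)N1C(=O)CCC1=O`, gives 0%. Both measured steps away from compound 1 ran downward: a number 50 percentage points lower from compound 1 to compound 2 (beyond the scatter), and a number 25 percentage points lower from compound 1 to compound 3 (beyond the scatter).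

The unmeasured compound 4 `CCC(C(=O)N1CCN(c2ccc(Cl)cc2)CC1)N1C(=O)CCC1=O` keeps the same atoms as compound 1 but joins them differently: 4-chlorophenyl in place of 2-chlorophenyl on an amine nitrogen in a ring. Neither measured step addresses this kind of change. The step to compound 2 replaces the group on the aromatic ring rather than relocating it, and the step to compound 3 shortens the saturated chain. What the two steps share is that every single alteration tried so far has lowered the read-out of compound 1, by a large amount in one case and a modest amount in the other. For the measured compounds named here, with no direct precedent for shifting the chlorine, the account expects a lower or unchanged result rather than a gain, and estimates a number 25 percentage points lower from compound 1 to compound 4 (beyond the scatter). Compound 4 is therefore expected to give about 25%, with a range from 0% to 50%.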

Compound 4, a percentage reported as activity, at one dose (the size of the read-out at that dose, not a potency): 25%
Beside the measured number, compound 4's estimate shows no gap at the digits printed; the range from low to high includes it.
By their numbers in this assay, from the lowest: compound 2; then compounds 3 and 4 (each within the scatter of the next); then compound 1.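

For the compounds shown here, replacing 2-chlorophenyl with 4-chlorophenyl on an amine nitrogen in a ring is the first step here that keeps the same atoms and changes only how they are joined, and in this assay that alone moves the read-out (a number 25 percentage points lower from compound 1 to compound 4 (beyond the scatter)). The earlier step to compound 2 exchanged the group on the aromatic ring, whereas this pair shows that, with the chlorine retained, the read-out of compound 1 also depends on where that chlorine sits, and all three single changes shown now give lower numbers than compound 1, with no compound going against this. No measurement is available that would explain this fall.

The compounds shown leave open whether an unsubstituted phenyl, or a fluoro, bromo or methoxy group in place of the chlorine, would keep the read-out of compound 1. They also leave open whether a propyl chain in place of the ethyl chain of compound 1 would continue the rise in the read-out seen from compound 3 to compound 1, or reverse it.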